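This account rests on a few compounds, and the source may have more. Where it says the series, first, only, none or still open, it means among the compounds named here.

Within the data shown here, in a functional assay on PC-3 cells (Homo sapiens) for inhibition, read by sulforhodamine B assay, with a stated time of 48 h (a lower number here means a stronger inhibitor of growth, a higher number a weaker inhibitor of growth), two compounds built on the same core have numbers so far. Compound 1 (`COc1ccc(/C=C/C2(C)C=CC(=O)O2)c(OC)c1`) gives 63500 nM. Compound 2 (`CC1(/C=C/c2ccccc2O)C=CC(=O)O1`) gives 112000 nM, and these two numbers lie within the scatter of each other, so neither can be ranked over the other. Compound 3 (`COc1ccccc1/C=C/C1(C)C=CC(=O)O1`) has not yet been measured. Its structure departs from that of compound 2 by one change, methyl in place of hydrogen on an oxygen on an aromatic ring, which reads as hydroxy to methoxy. Among the measured compounds shown here, no pair of measured compounds shows this change on its own, so the data give no direct size for it. Compound 1 does carry methoxy on its aromatic ring and gives 63500 nM, so no step beyond the scatter is expected in this assay, and no firm direction is expected either. For compound 3 the estimated value is 80000 nM, with an expected range from 40000 nM to 150000 nM. This estimate means an expected step of a 1.4-fold lower number from compound 2 to compound 3 (0.15 log units; within the scatter).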

Compound 3, concentration for total growth inhibition: 34200 nM
The estimate for compound 3 lay 2.3-fold (0.37 log units) above the measured number; measured number below the stated range.
By their numbers in this assay, from the lowest: compounds 3, 1 and 2 (each within the scatter of the next, the first and the last beyond it).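

In this assay, among these compounds, methyl in place of hydrogen on the oxygen on the aromatic ring gives a 3.3-fold lower number from compound 2 to compound 3 (0.52 log units; beyond the scatter), which is the first direct size for this change and the only step in this small set that lies beyond the scatter. The second methoxy of compound 1 adds nothing that can be read, since hydrogen in place of that methoxy on an aromatic carbon gives a 1.9-fold lower number from compound 1 to compound 3 (0.27 log units; within the scatter), and compound 1 and compound 3 therefore cannot be ranked. The data offer no measurement that would explain why hydroxy and methoxy differ at this oxygen.

Among the compounds shown here, the change rests on one pair of compounds, so it remains open whether it would hold with the second methoxy present, as compound 1 has no hydroxy counterpart here. On these data alone, it is also open whether a longer chain on the same oxygen, such as ethyl, would continue the step or reverse it, and whether an amine in place of the methoxy on the aromatic carbon would keep the number of compound 3.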